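A few compounds are considered here, and "the series" means these few. Any claim that something is new, unique, unknown or untested is made for them only; others in the source may bear on it.

Measured so far:

compound 1, `COc1cc(-c2nn(-c3cccc(NC(=O)c4ccc(Cl)c(C(F)(F)F)c4)c3)cc2-c2ccncc2)ccc1Cl`, 18700 nM in a functional assay on RXF 393 cells (Homo sapiens) for inhibition, read by sulforhodamine B assay, with a stated time of 48 h; a higher number here means a weaker inhibitor of growth, a lower number a stronger inhibitor of growth
compound 2, `O=C(Nc1cccc(-n2cc(-c3ccncc3)c(-c3ccc(Cl)c(O)c3)n2)c1)Nc1cc(C(F)(F)F)cc(C(F)(F)F)c1`, 2490 nM in this assay
compound 3, `COc1cc(-c2nn(-c3cccc(NC(=O)c4ccccc4)c3)cc2-c2ccncc2)ccc1Cl`, 6340 nM in this assay

Among these three, compound 2 gives the lowest number in this assay. Compound 3 is nearest to it, with a higher number that lies beyond the scatter, and compound 1 is furthest, with a still higher number, also beyond the scatter. Within the data shown here, the one step that can be traced between measured compounds runs from compound 1 to compound 3, where the group on the carbonyl carbon is simplified; that step gives a 2.9-fold lower number from compound 1 to compound 3 (0.47 log units; beyond the scatter).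

Compound 4, `O=C(Nc1cccc(-n2cc(-c3ccncc3)c(-c3ccc(Cl)c(O)c3)n2)c1)Nc1cccc(C(F)(F)F)c1`, has not yet been measured. It differs from compound 2 in one place: hydrogen in place of trifluoromethyl on an aromatic carbon. The change is a stripping of a fluorinated group from the terminal aromatic ring, and in that sense it resembles the step from compound 1 to compound 3, although that step removed two groups from an amide, whereas here one trifluoromethyl leaves a urea and a second trifluoromethyl remains. The analogy is therefore loose, and the step for compound 4 is expected to be small, most likely a lowering of the number that may not reach beyond the scatter, with a 1.4-fold lower number from compound 2 to compound 4 (0.14 log units; within the scatter). Compound 4 is estimated at 1800 nM, within a range from 800 nM to 4500 nM.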

Compound 4, concentration for total growth inhibition: 12000 nM
Beside the measured number, compound 4's estimate is 6.7-fold (0.82 log units) below it; the whole stated range lies below it.
By their numbers in this assay, from the lowest: compound 2; then compounds 3, 4 and 1 (each within the scatter of the next, the first and the last beyond it).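

In this assay, the step of a 4.8-fold higher number from compound 2 to compound 4 (0.68 log units; beyond the scatter) shows that the trifluoromethyl group at this place on the terminal ring of the urea is not interchangeable with hydrogen: the single remaining trifluoromethyl does not hold the number where it stood with two. Among these compounds, this runs opposite to the only earlier step, a 2.9-fold lower number from compound 1 to compound 3 (0.47 log units; beyond the scatter), where the chloro and trifluoromethyl groups both left an amide's terminal ring and the number fell, so these two steps give no single direction for stripping such a ring. Nothing shown gives a measured reason for this change or for the difference between the two steps.

The compounds shown leave open whether trifluoromethyl itself matters at this place, since only hydrogen has been compared with it here, and a chlorine, a nitrile, a methyl or an amine in its stead could tell more. They also leave open whether removing the other trifluoromethyl group would give a similar step, and whether the amide and the urea respond differently when the rest of the molecule is held the same.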